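Piperazine urea series: repeating the chloro step on compound 3

The compounds below may be only part of what the source reports. "The series", "measured", "known", "first", "only" and "open" are said of these compounds alone.

Measured compounds, with values in a functional assay on MDA-MB-231 cells (Homo sapiens) for antiproliferative activity, read by MTT assay, with a stated time of 24 h; on this read-out higher numbers stand for weaker inhibition and lower numbers for stronger inhibition:
compound 1 `O=C(Nc1ccccc1Cl)N1CCN(c2nccc(NCc3ccccc3)n2)CC1`, 1590 nM
compound 2 `O=C(Nc1ccc(Cl)cc1Cl)N1CCN(c2nccc(NCc3ccccc3)n2)CC1`, 9790 nM
compound 3 `COc1cccc(Nc2ccnc(N3CCN(C(=O)Nc4ccccc4Cl)CC3)n2)c1`, 5260 nM

Compound 2 differs from compound 1 by chloro in place of hydrogen on an aromatic carbon, and in this assay that change gave a 6.2-fold higher number from compound 1 to compound 2 (0.79 log units; beyond the scatter). Compound 3 differs from compound 1 in its core by 3-methoxyphenyl in place of benzyl on a nitrogen on an aromatic ring, a change that gave a 3.3-fold higher number from compound 1 to compound 3 (0.52 log units; beyond the scatter). Compound 2 and compound 3 lie within the scatter of each other.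

Compound 4 `COc1cccc(Nc2ccnc(N3CCN(C(=O)Nc4ccc(Cl)cc4Cl)CC3)n2)c1` is not yet measured. It differs from compound 3 by chloro in place of hydrogen on an aromatic carbon, the same change as that from compound 1 to compound 2, at the same place on the same ring. Within the data shown here, from compound 3 to compound 4 a step of a 5.3-fold higher number from compound 3 to compound 4 (0.73 log units; beyond the scatter) is expected, resting on the single precedent a 6.2-fold higher number from compound 1 to compound 2 (0.79 log units; beyond the scatter) seen on the other core. Compound 4 is accordingly estimated at 28000 nM, with a range from 9000 nM to 80000 nM.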

Compound 4, half-maximal inhibitory concentration: 11300 nM
Compound 4: the middle estimate sits 2.5-fold (0.39 log units) above what was measured; the range from low to high includes it.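

In this assay the chloro step keeps its direction on the second core with a 2.1-fold higher number from compound 3 to compound 4 (0.33 log units; beyond the scatter) but does not keep its size: the same change on two cores in this assay, a 6.2-fold higher number (0.79 log units; beyond the scatter) from compound 1 to compound 2 and a 2.1-fold higher number (0.33 log units; beyond the scatter) from compound 3 to compound 4, 2.9-fold (0.46 log units) apart, beyond the scatter of two such steps.
With 2,4-dichlorophenyl present, 3-methoxyphenyl in place of benzyl gives only a 1.2-fold higher number from compound 2 to compound 4 (0.06 log units; within the scatter), which does not match the step seen with 2-chlorophenyl: the same change on two cores in this assay, a 3.3-fold higher number (0.52 log units; beyond the scatter) from compound 1 to compound 3 and a 1.2-fold higher number (0.06 log units; within the scatter) from compound 2 to compound 4, 2.9-fold (0.46 log units) apart, beyond the scatter of two such steps.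
These four compounds show that neither step carries over at full size from one core to the other, but they do not show why, or how either step would behave on a further core.

Going by these compounds, it remains open whether a fluoro, a nitrile or an amine in place of the added chloro would give a step in the same direction. On these data alone, a longer chain in place of benzyl on the nitrogen is equally open.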